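The source may hold more compounds than are shown below. What is called first, only, known or untested is meant among the compounds shown, and "the series" means these compounds.

Measured so far in an assay on nucleic acid for inhibition of Nucleic Acid, read by fluorescence, tested at 100 uM; a higher number here means more inhibition at the concentration tested (going by the name of the read-out), a lower number less inhibition:
compound 1, `CCCCN(CCCC)Cc1cn(C2CCCCC2OC(=O)COc2ccccc2)nn1`: 26%
compound 2, `CCCCN(CCCC)Cc1cn(CC(O)COC(=O)C2CCCCC2)nn1`: 12%
compound 3, `CC(C)CCN(C)Cc1cn(CC(O)COC(=O)C2CCCCC2)nn1`: 0%

Compound 1 gives the highest of the three numbers in this assay; its nearest neighbour is compound 2, and both of its steps to the others are beyond the scatter. The difference between the core of compound 1 and the core of compound 2 is not broken down here. Within the core of compound 2, one change is measured: isopentyl(methyl)amino in place of dibutylamino on a saturated chain carbon bound to an aromatic carbon The step is a number 12 percentage points lower from compound 2 to compound 3 (beyond the scatter), a modest drop that lies beyond the scatter.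

Compound 4, `CC(C)CCN(C)Cc1cn(C2CCCCC2OC(=O)COc2ccccc2)nn1`, is not yet measured. It differs from compound 1 by exactly the same change: isopentyl(methyl)amino in place of dibutylamino on a saturated chain carbon bound to an aromatic carbon The place is the same in both pairs, word for word, so it is the same change made on a different core. Since this change occurs only twice among the compounds shown, the step from compound 2 to compound 3 is the sole measured guide to what it does, and a step of similar size is expected for compound 4, which rests on a number 12 percentage points lower from compound 2 to compound 3 (beyond the scatter) being beyond the scatter. The expected step is a number 12 percentage points lower from compound 1 to compound 4 (beyond the scatter), and the scatter of this read-out sets the width of the range. For compound 4 in this assay the estimate is 14%, with a range from 2% to 26% expected.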

Compound 4, a percentage reported as inhibition, at one concentration (the size of the read-out at that concentration, not a potency): 59%
Compound 4: middle estimate off by 45 percentage points, on the low side, and the stated range ends below it.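

In this assay, the swap of dibutylamino for isopentyl(methyl)amino on the core of compound 1 gives a number 33 percentage points higher from compound 1 to compound 4 (beyond the scatter), so the step measured on the core of compound 2 did not carry over in either size or direction: the same change on two cores in this assay, a number 12 percentage points lower (beyond the scatter) from compound 2 to compound 3 and a number 33 percentage points higher (beyond the scatter) from compound 1 to compound 4, 45 percentage points apart, beyond the scatter of two such steps. In this series, then, the same change cannot be transferred from one core to the other as a fixed increment, and the measured step on one core says little about the outcome on the other. Among the compounds shown here, this does not show which part of the cores is responsible or why the steps differ, and with only two pairs it gives no general rule for other cores; these are also readings at a single concentration, not potencies.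

The compounds shown leave open whether the rise seen on the core of compound 1 belongs to isopentyl(methyl)amino specifically or extends to other amines on that core, such as dimethylamino or piperidine. They also leave open how much of the difference between the two steps would remain on a core that carries only part of the difference between the core of compound 1 and the core of compound 2.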